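The source may report more compounds than this note shows. Statements on the series, on what has been measured and on what is new or still open speak of the compounds shown alone.

Working notes on a chromone series read in a functional assay on HepG2 cells (Homo sapiens) for cytotoxicity, read by MTT assay, with a stated time of 72 h; a higher number here means a weaker inhibitor, a lower number a stronger inhibitor. Compound 1 `O=C(COc1ccc(-c2cc(=O)c3ccccc3o2)cc1)NC1CCN(Cc2ccccc2)CC1` gives 15500 nM in this assay. Compound 2 `N#Cc1ccc(CN2CCC(NC(=O)COc3ccc4c(=O)cc(-c5ccccc5)oc4c3)CC2)cc1` gives 9300 nM in this assay, and compound 3 `COc1ccc(CN2CCC(NC(=O)C(C)(C)Oc3ccc4c(=O)cc(-c5ccccc5)oc4c3)CC2)cc1` gives 8700 nM; both of these numbers lie within the usual scatter of the number for compound 1, so the three compounds cannot be separated on what has been measured. Going by the values given here, no pair of measured compounds differs in only one place, so no step size is yet known for any single change.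

Compound 4 `O=C(COc1ccc(-c2cc(=O)c3ccccc3o2)cc1)NC1CCN(C(=O)c2ccccc2)CC1` is the next entry. Its difference from compound 1 is benzoyl in place of benzyl on an amine nitrogen in a ring. With no measured step of this kind in the series, the expectation for the move from compound 1 to compound 4 is a step of a 1.2-fold higher number from compound 1 to compound 4 (0.06 log units; within the scatter) that stays within the scatter in this assay, with no direction claimed. On that basis compound 4 is expected to give about 18000 nM in this assay, within a range of 7000 nM to 45000 nM.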

Compound 4, half-maximal inhibitory concentration: > 20000 nM
Compound 4: no number, only a limit; the forecaster's own chance of this, stated with the estimate: 10%; at least 1.1-fold (0.04 log units) between middle value and limit.
By their numbers in this assay, from the lowest: compounds 3, 2 and 1 (each within the scatter of the next). At a limit, above all of these: compound 4.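

In this assay compound 4 gives > 20000 nM, a limit of the assay and not a number. Going by these compounds alone, this gives the series its only single-place step, an at least 1.2-fold higher number from compound 1 to compound 4 (0.11 log units; that floor lies within the scatter), so at this ring nitrogen benzoyl in place of benzyl yields no lower number, though the change cannot be called a real rise. The full size of the step cannot be read from a floor: the limit of > 20000 nM in this assay, at which 1 of the 4 values shown sits.

Still open, going by these compounds, is how an acetyl group or a sulfonyl group on that nitrogen would read. Whether benzoyl acts alike on the cores of compound 2 and compound 3 is also unresolved.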